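The source may hold more compounds than are shown below. What is called first, only, known or untested is meant among the compounds shown, and "the series" means these compounds.

Compound 1 `CCN(CC)S(=O)(=O)c1ccc(S(=O)(=O)N2CCC[C@@H](C(=O)N3CCOCC3)C2)cc1` and compound 2 `O=C([C@@H]1CCCN(S(=O)(=O)c2ccc(S(=O)(=O)C3CC3)cc2)C1)N1CCC(F)(F)CC1` have both been tested in a functional assay on BXPC-3 cells (Homo sapiens) for inhibition, read by MTT assay, with a stated time of 7 days; on this read-out higher numbers stand for weaker inhibition and lower numbers for stronger inhibition. In this assay compound 1 gives 790 nM, the highest of the two numbers. Compound 2 gives 129 nM in this assay, a gap that lies beyond the scatter; but the two structures differ in several places at once, so this gap says nothing about any single change. Compound 3 `CCN(CC)S(=O)(=O)c1ccc(S(=O)(=O)N2CCC[C@@H](C(=O)N3CC[C@H](OC)C3)C2)cc1` has not yet been measured and differs from compound 1 in one place: 3-methoxypyrrolidin-1-yl in place of morpholin-4-yl on a carbonyl carbon. For the measured compounds named here, no measured pair shows this particular change, so the size of its effect is unknown. Because compound 1 sits at 790 nM and nothing else bears on this change, the step of a 1.1-fold lower number from compound 1 to compound 3 (0.05 log units; within the scatter) is expected to be small, with no direction beyond the scatter. Compound 3 is therefore estimated at 700 nM in this assay, within a range from 280 nM to 1800 nM.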

Compound 3, half-maximal inhibitory concentration: 6750 nM
Compound 3: the middle estimate sits 9.6-fold (0.98 log units) below what was measured; measured number above the stated range.
By their numbers in this assay, from the lowest: compound 2; then compound 1; then compound 3.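

In this assay, replacing morpholin-4-yl with 3-methoxypyrrolidin-1-yl on a carbonyl carbon gives an 8.5-fold higher number from compound 1 to compound 3 (0.93 log units; beyond the scatter), which means weaker inhibition, so the group on this carbonyl carbon matters to the result. The two groups have the same counts of hydrogen-bond donors and acceptors and carry no net charge, so those counts alone do not predict the outcome in this pair. Nothing measured here explains the size of this step.

This single change combines a five-membered ring in place of a six-membered one, a methoxy group and a defined stereocentre, and the pair cannot separate these features. Plain pyrrolidin-1-yl, which has no methoxy group, and piperidin-1-yl on the same core would be needed to show which feature tracks with the weaker inhibition.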